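Swapping methoxy for amino on a sulfonamide antagonist

The source may hold more compounds than are shown below. What is called first, only, known or untested is meant among the compounds shown, and "the series" means these compounds.

Compound 1 `COc1cc(C(=O)NS(=O)(=O)c2ccccc2OC)ccc1Cn1ccc2ccc(NC(=O)CC3CCCC3)cc21`: 9.7
Compound 2 `COC(=O)C(C(=O)c1ccc(Cn2ncc3ccc(NC(=O)OC4CCCC4)cc32)c(OC)c1)S(=O)(=O)c1ccccc1`: 9.9

Of the compounds shown here, two have been measured in a functional assay (trachea) for antagonist activity, with Cavia porcellus as the target; on this read-out lower numbers stand for lower potency and higher numbers for higher potency (the scale is a negative logarithm). Compound 1 gives 9.7 and compound 2 gives 9.9; the two numbers lie within the usual scatter of each other, so neither can be called the more potent, and compound 1 simply holds the lower of the two values. The two structures differ in several places at once, so no single change can be read from them.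

Compound 3 `COc1cc(C(=O)NS(=O)(=O)c2ccccc2N)ccc1Cn1ccc2ccc(NC(=O)CC3CCCC3)cc21` has not yet been tested in this assay. It differs from compound 1 in one place: amino in place of methoxy on an aromatic carbon. Going by the values given here, no measured pair shows this change, so its effect is unknown. Since the exchange keeps a group of similar size and a hydrogen-bond acceptor at the same place, the expected step from compound 1 to compound 3 in this assay is small, a number 0.20 log units lower from compound 1 to compound 3 (within the scatter), and may well stay within the scatter. Compound 3 is therefore expected to give about 9.5, with a range from 8.9 to 10.1.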

Compound 3, negative logarithm of the antagonist equilibrium constant: 9.9
Beside the measured number, compound 3's estimate is 0.40 log units below it; low and high end bracket the measured number.
By their numbers in this assay, from the lowest: compounds 1, 2 and 3 (each within the scatter of the next).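

In this assay, amino in place of methoxy on the aromatic carbon, ortho to a large group, gives a number 0.20 log units higher from compound 1 to compound 3 (within the scatter). Going by these compounds alone, this is the first comparison here that isolates a single change, and it shows that this read-out does not separate the two groups at this place on the core of compound 1, even though the 2-aminophenyl group of compound 3 has one heavy atom where the methoxy group has two and carries a hydrogen-bond donor where the methoxy group has none. No measurement available here bears on why the two groups read alike.

The compounds shown leave open how other groups at this carbon would read, such as a hydroxyl, a methyl, a dimethylamino group or a plain hydrogen, and so how much variety this place accepts before the number moves beyond the scatter. They also leave open whether the same exchange of methoxy for amino would give a similar step on a different core, such as that of compound 2.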